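A few compounds are considered here, and "the series" means these few. Any claim that something is new, unique, unknown or untested is made for them only; others in the source may bear on it.

In an ADME assay on Vero cells (Chlorocebus sabaeus) for inhibition (on this read-out higher numbers stand for lower toxicity in this test and lower numbers for higher toxicity in this test), compound 1 `COc1ccc(/C=C2\CCC/C(=C\c3ccc(OC)cc3)C2=O)cc1` gives 178000 nM, and compound 2 `COc1ccc(/C=C2\CCC/C(=C\c3ccc(Cl)cc3)C2=O)cc1` gives 401000 nM, the higher of the two numbers. Among the measured compounds shown here, only one measured step connects them: a 2.3-fold higher number from compound 1 to compound 2 (0.35 log units; beyond the scatter), a modest change beyond the usual scatter, with chloro in place of methoxy on an aromatic carbon. Compound 3 `COc1ccc(/C=C2\CCC/C(=C\c3ccc(Br)cc3)C2=O)cc1` is still to be measured. It keeps the core of compound 2 and carries bromo in place of chloro on an aromatic carbon, para to a large group: bromo in place of chloro on an aromatic carbon. The measured step involves the same kind of position, but it replaces methoxy and says nothing directly about exchanging chloro for bromo. For the measured compounds named here, no bromo compound has yet been measured in this assay for comparison. Going by the values given here, with a 2.3-fold higher number from compound 1 to compound 2 (0.35 log units; beyond the scatter) as the sole and only indirect guide, no step beyond the scatter is expected in either direction, and the estimate stays close to compound 2 at 401000 nM. The expected change is a 1.0-fold lower number from compound 2 to compound 3 (0.01 log units; within the scatter). Compound 3 is estimated at 390000 nM, with an expected range from 200000 nM to 760000 nM.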

Compound 3, half-maximal cytotoxic concentration: 250000 nM
Estimate against measurement, compound 3: 1.6-fold (0.19 log units) above; the range from low to high includes it.
By their numbers in this assay, from the lowest: compounds 1, 3 and 2 (each within the scatter of the next, the first and the last beyond it).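

In this assay the exchange of chloro for bromo on an aromatic carbon, para to a large group, can now be read directly as a 1.6-fold lower number from compound 2 to compound 3 (0.21 log units; within the scatter) and so does not tell the two halogens apart at this position. Replacing methoxy at the same place now reads differently for the two halogens, with a 1.4-fold higher number from compound 1 to compound 3 (0.15 log units; within the scatter) for bromo against a 2.3-fold higher number from compound 1 to compound 2 (0.35 log units; beyond the scatter) for chloro, so the step beyond the scatter seen earlier does not carry over to bromo, and compound 3 cannot be separated from either of the other two compounds. No measurement shown here bears on the reason for these numbers.

As far as these compounds go, how the read-out responds at this place to a quite different group, such as an amine, a carboxylic acid or a longer alkyl chain, remains open. Fluoro and iodo at the same position are also open, as is whether the exchange of chloro for bromo would read the same way on another core.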